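The source may report more compounds than this note shows. Statements on the series, on what has been measured and on what is new or still open speak of the compounds shown alone.

Measured so far in a physicochemical assay for solubility, read by spectrophotometry, in phosphate buffer, with a stated time of 2 h, at pH 7.4; a higher number here means a more soluble compound, a lower number a less soluble compound:
- compound 1 `COc1cccc(CN2C(=O)CN(C(=O)c3cc4cc(OC)ccc4o3)C[C@@H]2CCc2ccccc2)c1` gives 4900 nM
- compound 2 `COc1ccc2[nH]c(C(=O)N3CC(=O)N(Cc4ccccc4)[C@@H](CCc4ccccc4)C3)cc2c1` gives 4400 nM
- compound 3 `COc1ccc2[nH]c(C(=O)N3CC(=O)N(Cc4ccccc4)[C@@H](CN4CCN(Cc5ccccn5)CC4)C3)cc2c1` gives only a limit, > 100000 nM

In this assay compound 2 has the lowest of the two numbers, but its nearest neighbour, compound 1, sits within the scatter of it, so the two are not separable. Among the compounds with values here, compound 3 is a different case: its result is a limit, not a number, and is the one value sitting at the limit of > 100000 nM in this assay, at which 1 of the 3 values shown sits.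

Compound 4 `COc1ccc2[nH]c(C(=O)N3CC(=O)N(Cc4ccccc4)[C@@H](CN4CC5(CCC5)C4)C3)cc2c1` is not yet measured. It differs from compound 2 in one place: a group of 7 heavy atoms (6 carbon, 1 nitrogen; one four-membered non-aromatic ring of carbon only, one four-membered non-aromatic ring with 1 hetero atom) in place of a group of 7 heavy atoms (7 carbon; one six-membered aromatic ring of carbon only), on a saturated chain carbon bound to a saturated ring carbon

Within the data shown here, no measured step between two compounds differing in one place is available, so the size of this step in this assay rests on expectation only. A change of this kind is expected to move the number upward, well beyond the scatter, with a real chance that the assay again reports only a limit.

The step from compound 2 to compound 4 is expected to be an 11-fold higher number from compound 2 to compound 4 (1.06 log units; beyond the scatter).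

Compound 4 is therefore estimated at 50000 nM, with a range of 12000 nM to 100000 nM.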

Compound 4, solubility: 60700 nM
The estimate for compound 4 lay 1.2-fold (0.08 log units) below the measured number; the range from low to high includes it.
By their numbers in this assay, from the lowest: compounds 2 and 1 (each within the scatter of the next); then compound 4. At a limit, above all of these: compound 3.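

In this assay, within the data shown here, the exchange of benzyl for the group with two four-membered rings and one nitrogen, on a saturated chain carbon bound to a saturated ring carbon, gives the first readable step at this place: a 14-fold higher number from compound 2 to compound 4 (1.14 log units; beyond the scatter). This is a large step between two groups of equal heavy-atom count, and compound 4 still gives a number rather than a limit, so its full size can be read. Compound 3 remains a limit and not a number: the limit of > 100000 nM in this assay, at which 1 of the 4 values shown sits.

The compounds shown do not tell whether the step follows the nitrogen, the loss of the aromatic ring, or the two together. Cyclohexyl, with a saturated ring of carbon only, and an open-chain amine such as dimethylamino at this place would separate these readings.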